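Hydroxy for Methoxy: an Expected Cytotoxicity Read-out

The source may hold more compounds than are shown below. What is called first, only, known or untested is meant among the compounds shown, and "the series" means these compounds.

Measured compounds:
Compound 1, `COc1cc(C)cc(-c2nn(CC#N)cc2-c2ccc(-c3cccc(C(C)=O)c3)nc2)c1`: 96%
Compound 2, `Cc1cc(O)cc(-c2nn(CC#N)cc2-c2ccnc(-c3ccc(Oc4ccccc4)cc3)c2)c1`: 101%
Compound 3, `COc1cc(C)cc(-c2nn(CC#N)cc2-c2ccnc(-c3ccc(N(C)C)cc3)c2)c1`: 105%

In a functional assay on LOX IMVI cells (Homo sapiens) for cytotoxicity, read by sulforhodamine B assay, with a stated time of 48 h, tested at 0.01 uM (on this read-out lower numbers stand for a stronger effect and higher numbers for a weaker effect at the one concentration tested), compound 1 gives 96%, compound 2 gives 101%, and compound 3 gives 105%. The number for compound 3 lies within the scatter of the number for compound 2 and also within the scatter of the number for compound 1, so the three cannot be told apart on this read-out; none of them shows an effect of note at the one concentration tested. Among the measured compounds shown here, no pair of the measured compounds differs in a single place, so no measured step exists to lean on.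

Compound 4, `Cc1cc(O)cc(-c2nn(CC#N)cc2-c2ccnc(-c3ccc(N(C)C)cc3)c2)c1`, differs from compound 3 in one place: hydrogen in place of methyl on an oxygen on an aromatic ring. Compound 2 already carries the 3-hydroxy-5-methylphenyl group and gives 101%, a number within the scatter of the others. The step from compound 3 to compound 4 is therefore expected to be none beyond the scatter, a number 4 percentage points lower from compound 3 to compound 4 (within the scatter). Compound 4 is estimated to give 101%, with a range from 90% to 112%.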

Compound 4, a percentage reported as activity, at one concentration (the size of the read-out at that concentration, not a potency): 104%
The estimate for compound 4 lay 3 percentage points below the measured number, within the range that was stated.
By their numbers in this assay, from the lowest: compounds 1, 2, 4 and 3 (each within the scatter of the next).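

In this assay, among the compounds shown here, the change from methoxy to hydroxy on the aromatic ring gives a number 1 percentage points lower from compound 3 to compound 4 (within the scatter), so this is the first measured step at this oxygen, and it cannot be told from the scatter. With the 3-hydroxy-5-methylphenyl group held in place, dimethylamino in place of phenoxy gives a number 3 percentage points higher from compound 2 to compound 4 (within the scatter), so this second change on the far aromatic ring cannot be told from the scatter either. No measurement at hand bears on either step.

Going by these compounds, it remains open whether a longer chain on this oxygen, such as ethoxy or propoxy, or an amine in place of the hydroxy would shift the read-out. Since both steps rest on one low concentration at which none of these compounds shows an effect of note, it also remains open whether the methoxy and hydroxy compounds would separate at a higher concentration.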